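The source may report more compounds than this note shows. Statements on the series, on what has been measured and on what is new or still open speak of the compounds shown alone.

In a functional assay on isolated protein for inhibition of Glucose-dependent insulinotropic receptor (Rattus norvegicus), read by HTRF and cAMP accumulation (a lower number here means that less compound is needed, a higher number that more compound is needed for the effect), the three measured compounds give these numbers:

compound 1 `Cc1nc(S(C)(=O)=O)ccc1Oc1ncnc(OC2CCN(C(=O)OC3(C(F)(F)F)CCC3)CC2)c1F`: 63.3 nM
compound 2 `Cc1nc(S(C)(=O)=O)ccc1Oc1ncnc(OC2CCN(C(=O)OC3(C(F)(F)F)COC3)CC2)c1F`: 342 nM
compound 3 `Cc1nc(S(C)(=O)=O)ccc1Oc1ncnc(OC2CCN(C(=O)SC3CC3)CC2)c1F`: 126 nM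

Compound 1 stands lowest of the three numbers. Compound 3 is nearest, with a 2.0-fold higher number from compound 1 to compound 3 (0.30 log units; within the scatter), a step within the scatter, and compound 2 is furthest, with a 5.4-fold higher number from compound 1 to compound 2 (0.73 log units; beyond the scatter).

Compound 4 `Cc1nc(S(C)(=O)=O)ccc1Oc1ncnc(OC2CCN(C(=O)c3noc(C(C)(C)F)n3)CC2)c1F` is not yet measured. It differs from compound 1 in one place: a group of 9 heavy atoms (5 carbon, 2 nitrogen, 1 oxygen, 1 fluorine; one five-membered aromatic ring with 3 hetero atoms) in place of a group of 9 heavy atoms (5 carbon, 1 oxygen, 3 fluorine; one four-membered non-aromatic ring of carbon only), on a carbonyl carbon. The change sits on a carbonyl carbon whose other neighbour is an amide-type nitrogen in a ring, the same place that is varied in the two measured steps. a 5.4-fold higher number from compound 1 to compound 2 (0.73 log units; beyond the scatter) shows that putting a four-membered ring with one hetero atom in place of a four-membered ring of carbon only at this position gives a modest step toward a higher number. a 2.0-fold higher number from compound 1 to compound 3 (0.30 log units; within the scatter) shows that a much smaller group on the same carbonyl carbon moves the number only within the scatter. Neither step puts an aromatic ring there, so the guide is loose. A modest step toward a higher number is expected, a 1.9-fold higher number from compound 1 to compound 4 (0.28 log units; within the scatter). Compound 4 is therefore estimated at 120 nM, with a range from 40 nM to 400 nM.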

Compound 4, half-maximal effective concentration: 103 nM
Compound 4: middle estimate off by 1.2-fold (0.07 log units), on the high side, within the range that was stated.
By their numbers in this assay, from the lowest: compounds 1, 4 and 3 (each within the scatter of the next); then compound 2.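

An aromatic ring is tolerated on this carbonyl carbon: in this assay, the five-membered aromatic ring with 3 hetero atoms gives a 1.6-fold higher number from compound 1 to compound 4 (0.21 log units; within the scatter), and the comparison with the much smaller sulfur-linked cyclopropyl group gives a 1.2-fold lower number from compound 3 to compound 4 (0.09 log units; within the scatter), so compound 4 cannot be told apart from compound 1 or compound 3. The 3-(trifluoromethyl)oxetan-3-yl group remains set apart, with a 3.3-fold lower number from compound 2 to compound 4 (0.52 log units; beyond the scatter), so a group with several hetero atoms need not carry the higher number seen with that oxetane. No measurement shown here explains why these groups match or differ.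

Among the compounds shown here, with one aromatic ring as the only example, it remains unknown whether a plain phenyl ring or a pyridine ring on the same carbonyl carbon would give a similar number in this assay, or whether the result depends on the five-membered ring with its 3 hetero atoms. Going by these compounds, it is also open how this ring would fare if its fluorine-bearing substituent gave way to a simple methyl group or to an amine.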